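A few compounds are considered here, and "the series" means these few. Any claim that something is new, unique, unknown or untested is made for them only; others in the source may bear on it.

Compound 1 `COCC(=O)NC1CCN(c2nc(C)c3cc(NC(=O)/C=C/c4ccc(OC(F)(F)F)cc4)ccc3n2)CC1` is the anchor of this small set. In an assay on CHO-K1 cells for displacement of a labelled ligand from melanin-concentrating hormone receptor 1 (Homo sapiens), read by scintillation proximity assay, with a stated time of 2 h (a higher number here means a weaker inhibitor, a lower number a stronger inhibitor), compound 1 gives 32 nM. Among the compounds with values here, its one measured neighbour, compound 2 `Cc1nc(NCCCNS(C)(=O)=O)nc2ccc(NC(=O)/C=C/c3ccc(OC(F)(F)F)cc3)cc12`, gives 54 nM in this assay, and the single step, a 1.7-fold higher number from compound 1 to compound 2 (0.23 log units; within the scatter), does not separate the two compounds. Within the data shown here, compound 1 therefore stands with one of only two numbers, and the scatter covers both.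

Compound 3 `Cc1nc(N2CCC(N3CCN(C)C3=O)CC2)nc2ccc(NC(=O)/C=C/c3ccc(OC(F)(F)F)cc3)cc12` is not yet measured. It differs from compound 1 by 3-methyl-2-oxoimidazolidin-1-yl in place of ((methoxymethyl)carbonyl)amino on a saturated ring carbon. Among the measured compounds shown here, no measured step touches this position: the step from compound 1 to compound 2 replaced the whole group on the aromatic carbon rather than the substituent on the saturated ring carbon, so it bears on the new change only by showing that the shared core tolerated a different group there without a step beyond the scatter. On that slender basis, compound 3 is expected to stay close to compound 1, with a step of a 1.3-fold higher number from compound 1 to compound 3 (0.10 log units; within the scatter) in this assay. Compound 3 is thus estimated at 40 nM, within a range of 15 nM to 120 nM.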

Compound 3, half-maximal inhibitory concentration: 21 nM
Estimate against measurement, compound 3: 1.9-fold (0.28 log units) above, and the stated range covers the measured number.
By their numbers in this assay, from the lowest: compounds 3, 1 and 2 (each within the scatter of the next, the first and the last beyond it).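

In this assay, the step at the saturated ring carbon itself, a 1.5-fold lower number from compound 1 to compound 3 (0.18 log units; within the scatter), does not separate the two compounds, although the open ((methoxymethyl)carbonyl)amino group, with 1 hydrogen-bond donor, gives way to 3-methyl-2-oxoimidazolidin-1-yl, a five-membered non-aromatic ring with 0 hydrogen-bond donors. For this one pair, then, the position, three ring bonds from the ring nitrogen, takes a closed ring in place of an open chain, and gives up the donor, without a step beyond the scatter, which the earlier step, a replacement of the whole group on the aromatic carbon, could not show. No measurement is available that would explain why the two groups give numbers this close.

The compounds shown do not tell whether the ring or its methyl group carries any weight, since a 2-oxoimidazolidin-1-yl group without the methyl, or a six-membered cyclic urea, does not appear among them. From the compounds shown here alone, both groups at this carbon also carry no net charge, so how a primary amine or a carboxylic acid would read here remains open.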